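Hydroxy for methoxy on the benzimidazole-phenol series, cytotoxicity

The source may report more compounds than this note shows. Statements on the series, on what has been measured and on what is new or still open speak of the compounds shown alone.

Measured so far:
compound 1 `COc1ccc(-c2nc3cc(Cl)c(Cl)cc3[nH]2)cc1`: 18000 nM
compound 2 `Oc1ccc(-c2nc3cc(C(F)(F)F)ccc3[nH]2)cc1`: > 100000 nM

Going by the values given here, in an ADME assay on BHK cells (Mesocricetus auratus) for cytotoxicity, read by MTT assay, with a stated time of 96 h (a lower number here means that less compound is tolerated, a higher number that more compound is tolerated), compound 1 gives 18000 nM, the only plain number in the set. Compound 2 gives > 100000 nM, which is a limit of the assay and not a number. Among the compounds with values here, compound 1 therefore stands as the one compound with a defined value, while the other entry sits at the limit of > 100000 nM in this assay, at which 1 of the 2 values shown sits.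

Compound 3 `Oc1ccc(-c2nc3cc(Cl)c(Cl)cc3[nH]2)cc1` is not yet measured. It differs from compound 1 by hydrogen in place of methyl on an oxygen on an aromatic ring. Within the data shown here, no measured pair differs in one place, so no step can be read directly. Compound 2 also carries the hydroxy group and sits at the limit of > 100000 nM in this assay, at which 1 of the 2 values shown sits; on that basis an upward step in this assay, beyond the usual scatter, is expected: a 2.8-fold higher number from compound 1 to compound 3 (0.44 log units; beyond the scatter). Compound 3 is accordingly estimated at 50000 nM, with a range from 15000 nM to 150000 nM.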

Compound 3, half-maximal cytotoxic concentration: 29000 nM
For compound 3 the middle estimate is 1.7-fold (0.24 log units) above the measured one; low and high end bracket the measured number.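

In this assay, the change from methoxy to hydroxy can now be read directly on one shared core: a 1.6-fold higher number from compound 1 to compound 3 (0.21 log units; within the scatter). On the core of compound 1, hydrogen in place of methyl on this oxygen therefore gives no separation beyond the usual scatter, and compound 1 and compound 3 cannot be ordered in this assay. Compound 2 also carries the hydroxy group, but its core differs and its entry is a limit of the assay, not a number: the limit of > 100000 nM in this assay, at which 1 of the 3 values shown sits.

Steps involving compound 2 cannot be read, so it remains open whether the same change would read alike on its core. Also open, from the compounds shown here alone, is how this assay would respond to a longer chain such as ethoxy on this oxygen, or to an amine or a carboxylic acid in its place.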